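Isobutoxy in Place of Isopentyloxy

The source may hold more compounds than are shown below. What is called first, only, known or untested is meant among the compounds shown, and "the series" means these compounds.

Of the compounds shown here, three built around a shared core have been tested in a functional assay on HCT-15 cells (Homo sapiens) for antiproliferative activity, read by XTT assay; a lower number here means a stronger inhibitor, a higher number a weaker inhibitor. Compound 1, `CC(C)CCOc1cccc2occ(Cc3coc4ccccc4c3=O)c(=O)c12`, reaches only the edge of the measurement: in this assay compound 1 gives > 10000 nM, which is a limit rather than a number. Compound 2, `O=c1c(CCc2coc3ccccc3c2=O)coc2ccccc12`, likewise gives > 10000 nM, again a limit. Compound 3, `O=C1c2c(OCC3CCCCC3)cccc2OCC1Cc1coc2ccccc2c1=O`, carries a cyclohexylmethoxy group where compound 1 has isopentyloxy, and in this assay compound 3 gives 8360 nM. Thus compound 1 sits at the limit of > 10000 nM in this assay, at which 2 of the 3 values shown sit, and none of the measured compounds shows marked inhibition.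

Compound 4, `CC(C)COc1cccc2occ(Cc3coc4ccccc4c3=O)c(=O)c12`, is compound 1 with a single change: isopropyl in place of isobutyl on a saturated chain carbon bound to an oxygen on an aromatic ring. Read one bond further out, the isopentyloxy group becomes isobutoxy. Within the data shown here, no measured pair shows what such a change does in this assay. With both the isopentyloxy and the cyclohexylmethoxy compounds weak, no move beyond the scatter is expected. The step that the limit leaves unreadable from compound 1 to compound 4 is expected to be small and in no fixed direction. Compound 4 is estimated at 12000 nM, within 5000 nM to 30000 nM, and most likely only a limit will be reported.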

Compound 4, half-maximal inhibitory concentration: > 10000 nM
Compound 4 ended at the assay's limit (the forecaster's own chance of this, stated with the estimate: 70%); the middle value does not contradict the limit.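

Compound 1 and compound 4 each give only a limit in this assay, not a number, so no step between them can be read: the limit of > 10000 nM in this assay, at which 3 of the 4 values shown sit.

From the compounds shown here alone, how strongly either compound truly acts, and whether isobutoxy and isopentyloxy differ at all, remains open.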